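Methoxy restored at the ring position of compound 3

The source may hold more compounds than are shown below. What is called first, only, known or untested is meant among the compounds shown, and "the series" means these compounds.

Of the compounds shown here, three sharing one core have been measured in an assay on IMR-32 cells for displacement of a labelled ligand from corticotropin-releasing factor receptor 1 (Homo sapiens), read by scintillation counting, with a stated time of 2 h; a higher number here means a weaker inhibitor, a lower number a stronger inhibitor. Compound 1 `CCC(CC)Nc1nc(OC)c(-c2ccc(Cl)cc2Cl)nc1C` gives 14.4 nM, compound 2 `CCc1nc(NC(CC)CC)c(Cl)nc1-c1ccc(Cl)cc1Cl` gives 71 nM, and compound 3 `CCc1nc(NC(CC)CC)cnc1-c1ccc(Cl)cc1Cl` gives 545 nM, the highest of the three numbers. Going by the values given here, the only single-point step among them, a 7.7-fold higher number from compound 2 to compound 3 (0.89 log units; beyond the scatter), shows that removing the substituent at that ring carbon weakens binding. Compound 4 `CCc1nc(NC(CC)CC)c(OC)nc1-c1ccc(Cl)cc1Cl` reverses that loss with a different group: methoxy in place of hydrogen on an aromatic carbon. Compound 1, which carries a methoxy at the same position, sits far lower than compound 3, so a return toward that level is expected. The expected step is a 22-fold lower number from compound 3 to compound 4 (1.34 log units; beyond the scatter). Compound 4 is therefore estimated to give 25 nM, with a range from 8 nM to 80 nM in this assay.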

Compound 4, inhibition constant: 5.9 nM
For compound 4 the middle estimate is 4.2-fold (0.63 log units) above the measured one; measured number below the stated range.
By their numbers in this assay, from the lowest: compound 4; then compound 1; then compound 2; then compound 3.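

In this assay, methoxy at this ring carbon brings a 92-fold lower number from compound 3 to compound 4 (1.97 log units; beyond the scatter), and the same group in place of chloro brings a 12-fold lower number from compound 2 to compound 4 (1.08 log units; beyond the scatter), so the position does more than favour any substituent over hydrogen. The identity of the group matters here, with methoxy ahead of chloro by a step beyond the scatter. Nothing shown explains why methoxy gives the lower number. As far as these compounds go, whether ethoxy, methylamino or fluoro at this carbon would give a still lower number remains open. So does whether the methoxy gain would hold with a methyl group in place of the ethyl group.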